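The compounds below may be only part of what the source reports. "The series", "measured", "known", "first", "only" and "open" are said of these compounds alone.

Working notes on the series. In an assay on isolated protein for inhibition of Fatty-acid amide hydrolase 1 (Rattus norvegicus), with a stated time of 60 min (a lower number here means a stronger inhibitor, a higher number a weaker inhibitor), compound 2 `O=C(Nc1noc2ccccc12)N1CCN(Cc2cccc(Oc3ccc(Cl)cc3)c2)CC1` gives 8.1 nM, the lowest number of the three measured, with compound 3 `O=C(Nc1noc2ccncc12)N1CCN(Cc2cccc(Oc3ccc(Cl)cc3)c2)CC1` at 2200 nM and compound 1 `O=C(Nc1cccc2cn[nH]c12)N1CCN(Cc2cccc(Oc3ccc(Cl)cc3)c2)CC1` at 6000 nM. Compound 4 `O=C(Nc1cccn2ccnc12)N1CCN(Cc2cccc(Oc3ccc(Cl)cc3)c2)CC1` differs from compound 2 by a group of 9 heavy atoms (7 carbon, 2 nitrogen; one five-membered aromatic ring with 2 hetero atoms, one six-membered aromatic ring with 1 hetero atom) in place of a group of 9 heavy atoms (7 carbon, 1 nitrogen, 1 oxygen; one five-membered aromatic ring with 2 hetero atoms, one six-membered aromatic ring of carbon only), on an amide-type nitrogen. Among the measured compounds shown here, two measured steps bear on this change of the bicyclic group on the amide-type nitrogen: a 740-fold lower number from compound 1 to compound 2 (2.87 log units; beyond the scatter) and a 270-fold higher number from compound 2 to compound 3 (2.43 log units; beyond the scatter), both large, showing that any replacement of the group in compound 2 seen so far moves the number far upward. A large step upward is therefore expected in this assay, a 190-fold higher number from compound 2 to compound 4 (2.27 log units; beyond the scatter), though with wide uncertainty as compound 4 carries a bicycle not yet tested. Compound 4 is estimated at 1500 nM, within 150 nM to 15000 nM.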

Compound 4, half-maximal inhibitory concentration: 3500 nM
Compound 4: middle estimate off by 2.3-fold (0.37 log units), on the low side, and the stated range covers the measured number.
By their numbers in this assay, from the lowest: compound 2; then compounds 3, 4 and 1 (each within the scatter of the next, the first and the last beyond it).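

On the amide-type nitrogen, a third replacement of the group in compound 2 gives a 430-fold higher number from compound 2 to compound 4 (2.64 log units; beyond the scatter), so in this assay the low number still belongs to compound 2 alone. The steps of a 1.6-fold higher number from compound 3 to compound 4 (0.20 log units; within the scatter) and a 1.7-fold lower number from compound 1 to compound 4 (0.23 log units; within the scatter) show that the group in compound 4, although it has a different set of hetero atoms, does not separate from the groups in the two weaker compounds. Nothing available here bears on the reason for these results. On these data alone, whether a single phenyl ring on the amide-type nitrogen, or a chlorine or methoxy group on the six-membered ring of the group in compound 2, would keep the low number remains open.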